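Swapping fluoro for trifluoromethyl in compound 3

A few compounds are considered here, and "the series" means these few. Any claim that something is new, unique, unknown or untested is made for them only; others in the source may bear on it.

Measured so far in an ADME assay on Vero cells (Chlorocebus sabaeus) for cytotoxicity, read by resazurin assay, with a stated time of 72 h; on this read-out higher numbers stand for weaker inhibition and lower numbers for stronger inhibition:
- compound 1 `O=C(CCN1CCN(c2ccc(C(F)(F)F)cc2)CC1)c1ccccc1`: 15700 nM
- compound 2 `COc1ccc(C(=O)CCN2CCN(c3ccc(C(F)(F)F)cc3)CC2)cc1`: 135000 nM
- compound 3 `O=C(CCN1CCN(c2ccc(F)cc2)CC1)c1ccc(F)c(Cl)c1`: 185000 nM

Compound 3, at 185000 nM, cannot be told apart from compound 2, at 135000 nM, since their gap lies within the usual scatter of repeated measurements. The gap from both of them to compound 1 lies beyond that scatter.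

The next compound, compound 4 `O=C(CCN1CCN(c2ccc(C(F)(F)F)cc2)CC1)c1ccc(F)c(Cl)c1`, has trifluoromethyl in place of fluoro on an aromatic carbon. Going by the values given here, no measured pair makes this exact change. Among the compounds with values here, the only measured step, an 8.6-fold higher number from compound 1 to compound 2 (0.93 log units; beyond the scatter), is a different change, methoxy in place of hydrogen, so it offers only a sense of scale: one substitution moved the number modestly. Compound 1 and compound 2 already carry the trifluoromethyl that compound 4 gains, but they disagree. Compound 1 lies well below compound 3, whereas compound 2 does not, so the evidence for a fall is weak.

In this assay the expected change is modest and towards stronger inhibition, a 3.7-fold lower number from compound 3 to compound 4 (0.57 log units; beyond the scatter). For compound 4 the estimated value is 50000 nM, with an expected range from 12000 nM to 170000 nM.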

Compound 4, half-maximal inhibitory concentration: 74500 nM
Compound 4: middle estimate off by 1.5-fold (0.17 log units), on the low side, and the stated range covers the measured number.
By their numbers in this assay, from the lowest: compound 1; then compounds 4, 2 and 3 (each within the scatter of the next, the first and the last beyond it).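

In this assay, trifluoromethyl in place of fluoro, para to a large group, is now measured directly with the rest of the molecule held fixed, and it gives a modest move towards stronger inhibition (a 2.5-fold lower number from compound 3 to compound 4 (0.40 log units; beyond the scatter)). With trifluoromethyl kept in place, the group on the carbonyl carbon also matters: 3-chloro-4-fluorophenyl in place of phenyl moves the number modestly the other way (a 4.7-fold higher number from compound 1 to compound 4 (0.68 log units; beyond the scatter)), so trifluoromethyl alone does not set the value. By contrast, 3-chloro-4-fluorophenyl in place of 4-methoxyphenyl leaves the two compounds indistinguishable (a 1.8-fold lower number from compound 2 to compound 4 (0.26 log units; within the scatter)), so among these three trifluoromethyl compounds, only the one with plain phenyl stands apart.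

Going by these compounds, whether a nitrile or a carboxylic acid on that same ring carbon would shift the number further, and whether the trifluoromethyl step repeats with plain phenyl on the carbonyl carbon, remains open. No measurement shown here explains why any of these numbers moved.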